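Notes on a fluoro substitution in the series

The compounds below may be only part of what the source reports. "The series", "measured", "known", "first", "only" and "open" are said of these compounds alone.

Compound 1 `O=C1COCCN1c1ccc(/N=C\c2c[nH]c3ccccc23)cc1` and compound 2 `O=C1COCCN1c1ccc(/N=C\c2cn(Cc3ccccc3)c3ccccc23)cc1` share one core and differ at a single place. In an ADME assay on BV-2 cells (Mus musculus) for cytotoxicity, read by MTT assay, with a stated time of 48 h, tested at 60 uM (a higher number here means a weaker effect of the compound at the concentration tested, a lower number a stronger effect), compound 1 gives 90.8%, and compound 2 gives 65%. Within the data shown here, the one measured step, a number 25.8 percentage points lower from compound 1 to compound 2 (beyond the scatter), comes from benzyl in place of hydrogen on an aromatic nitrogen. On the two numbers available, compound 2 stands at the lower one, with compound 1 above it by a margin beyond the scatter.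

Among the measured compounds shown here, compound 3 `O=C1COCCN1c1ccc(/N=C\c2cn(Cc3ccc(F)cc3)c3ccccc23)cc1` is the next member and has not been measured. fluoro in place of hydrogen on an aromatic carbon The only measured step concerns a change at the aromatic nitrogen and not fluoro on an aromatic carbon, so nothing in the data speaks directly to this substitution; that step was modest and does not carry over. Expected in this assay is therefore no step beyond the scatter, a number 3 percentage points lower from compound 2 to compound 3 (within the scatter). Compound 3 is estimated to give about 62%, within a range from 45% to 80%.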

Compound 3, a percentage reported as activity, at one concentration (the size of the read-out at that concentration, not a potency): 67.4%
Compound 3: middle estimate off by 5.4 percentage points, on the low side; the range from low to high includes it.
By their numbers in this assay, from the lowest: compounds 2 and 3 (each within the scatter of the next); then compound 1.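

In this assay, among these compounds, this is the first look at the outer ring of the benzyl group, and hydrogen to fluoro on this aromatic carbon gives a number 2.4 percentage points higher from compound 2 to compound 3 (within the scatter), so at this place, para to a large group, the two compounds cannot be told apart. The step from the free aromatic nitrogen holds with the fluorinated group as well: a number 23.4 percentage points lower from compound 1 to compound 3 (beyond the scatter) stands beyond the scatter, as a number 25.8 percentage points lower from compound 1 to compound 2 (beyond the scatter) does for benzyl, so on these three compounds the separation from compound 1 goes with substitution on the nitrogen and is not lost when 4-fluorobenzyl replaces benzyl. No measurement accompanies these numbers that would explain the result.

Among the compounds shown here, a single fluorine is the only change tried on this ring here, so it remains open whether a chlorine, a methoxy group or an amine on the same aromatic carbon would also stay within the scatter of compound 2. Also open, going by these compounds, is whether a longer chain or a carboxylic acid in place of the benzyl group on the aromatic nitrogen would move the read-out further from that of compound 1.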